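This account rests on a few compounds, and the source may have more. Where it says the series, first, only, none or still open, it means among the compounds named here.

Compound 1 `COc1ccc([C@@H]2CC(=O)c3cc(CC=C(C)C)c(OC)cc3O2)cc1` gives 68% 
Compound 2 `COc1ccc([C@@H]2C/C(=N/OCc3cn(-c4ccc(Cl)cc4C)nn3)c3cc(CC=C(C)C)c(OC)cc3O2)cc1` gives 20% 
Compound 3 `COc1ccc([C@@H]2C/C(=N/OCc3cn(-c4ccccc4CO)nn3)c3cc(CC=C(C)C)c(OC)cc3O2)cc1` gives 100% 

Among the measured compounds shown here, all three numbers come from a functional assay on HCT-116 cells (Homo sapiens) for inhibition, read by sulforhodamine B assay, with a stated time of 48 h, tested at 50 uM (on this read-out higher numbers stand for more inhibition of growth at the one concentration tested and lower numbers for less inhibition of growth), and form the whole of the data on this series so far. Compound 1 stands second highest of the three, with compound 3 above it and compound 2 below it, and both gaps lie beyond the scatter.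

Still unmeasured is compound 4 `COc1cc2c(cc1CC=C(C)C)C(=O)C[C@@H](c1ccc(Oc3ccccc3)cc1)O2` in which the structure departs from compound 1 by phenyl in place of methyl on an oxygen on an aromatic ring as phenyl in place of methyl on an oxygen on an aromatic ring, that is, methoxy to phenoxy. For the measured compounds named here, no measured step touches this place. Going by the values given here, the one measured step, a number 80 percentage points higher from compound 2 to compound 3 (beyond the scatter) and large, lies elsewhere, on an aromatic nitrogen, and gives no direction for this change. Among the compounds with values here, it shows only that exchanging one group in compound 2 can move the number a long way, which argues for a wide range here.

In this assay the estimated change is a number 6 percentage points lower from compound 1 to compound 4 (within the scatter) and no step beyond the scatter is expected. The estimate for compound 4 is 62% within an expected range of 30% to 92% on this read-out.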

Compound 4, percent growth inhibition at one concentration: 76%
Compound 4: the middle estimate sits 14 percentage points below what was measured; low and high end bracket the measured number.
By their numbers in this assay, from the lowest: compound 2; then compounds 1 and 4 (each within the scatter of the next); then compound 3.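

In this assay, among the compounds shown here, the exchange of methoxy for phenoxy gives a number 8 percentage points higher from compound 1 to compound 4 (within the scatter) as the first reading at this place, so a phenyl with its six carbon atoms and one six-membered aromatic ring can stand on this oxygen in place of a single methyl carbon with no step beyond the scatter. For the compounds shown here, the earlier compounds showed only that a change on an aromatic nitrogen can move the number a long way, as in a number 80 percentage points higher from compound 2 to compound 3 (beyond the scatter), whereas this much larger group on an oxygen on an aromatic ring leaves compound 1 and compound 4 level within the scatter of each other. No measurement at hand accounts for this outcome.

On these data alone, one exchange at this oxygen does not define the range of groups accepted here, and it remains open whether a benzyl group, a longer chain ending in an amine, or one ending in a carboxylic acid would also keep the number within the scatter. As far as these compounds go, it also remains open whether phenoxy gives the same outcome when combined with the 2-(hydroxymethyl)phenyl group of compound 3.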